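One Exchange on a Sulfonamide Nitrogen

The compounds below may be only part of what the source reports. "The series", "measured", "known", "first", "only" and "open" are said of these compounds alone.

Of the compounds shown here, three that share a core have been tested in a functional assay on SF-268 cells (Homo sapiens) for antiproliferative activity, read by sulforhodamine B assay, with a stated time of 72 h (a higher number here means a weaker inhibitor, a lower number a stronger inhibitor), and their numbers lie close together. Compound 1 `CCN1C(=O)CS/C1=N/Nc1nncc2ccccc12` gives 6 nM while compound 2 `Cc1cc(C)nc(NS(=O)(=O)c2ccc(Nc3nncc4ccccc34)cc2)n1` gives 7.6 nM and compound 3 `Clc1ccc(C(/C=C/c2ccccc2)=N\Nc2nncc3ccccc23)cc1` gives 6.3 nM as its result. Compound 2 stands level with both of the others: its number lies within the usual scatter of repeated measurements from each, so no order among the three can be read.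

Compound 4 `O=S(=O)(Nc1ccccn1)c1ccc(Nc2nncc3ccccc23)cc1` has not been measured yet. It differs from compound 2 by one exchange on the sulfonamide nitrogen: pyridin-2-yl in place of 4,6-dimethylpyrimidin-2-yl on a sulfonamide nitrogen while the rest of the structure stays the same.

Among the measured compounds shown here, no measured pair isolates an exchange of this kind, so the data give no direct guide to its size. Still, compound 1 at 6 nM and compound 3 at 6.3 nM carry quite different attachments on the core and remain within the scatter of compound 2 at 7.6 nM in these tests. The step of a 1.1-fold higher number from compound 2 to compound 4 (0.02 log units; within the scatter) is therefore expected to stay within the scatter, with no clear direction. For compound 4 the estimated value is 8 nM with an expected range from 3 nM to 25 nM in this assay once it is measured.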

Compound 4, half-maximal inhibitory concentration: 25 nM
Estimate against measurement, compound 4: 3.1-fold (0.49 log units) below; the measured number falls inside the stated range.
By their numbers in this assay, from the lowest: compounds 1, 3 and 2 (each within the scatter of the next); then compound 4.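

Among the compounds shown here, the exchange of 4,6-dimethylpyrimidin-2-yl for pyridin-2-yl on a sulfonamide nitrogen gives a 3.3-fold higher number from compound 2 to compound 4 (0.52 log units; beyond the scatter) in this assay, the first change here that can be read on its own and one that yields a weaker inhibitor. The group at this position therefore matters to the result, even though compounds with very different attachments on the shared core gave numbers within the scatter of one another. The entering pyridin-2-yl has fewer heavy atoms, hetero atoms and hydrogen-bond acceptors than the group it replaces, but these differences arrive together in a single step, and no measurement shown explains the loss.

The compounds shown leave open which part of the exchange carries the step, and a pyrimidin-2-yl with no methyl groups on the same sulfonamide nitrogen would separate the methyl groups from the ring itself. They also leave open how far this position tolerates other groups, such as a phenyl ring or a short chain like methyl, since a single step cannot establish a trend.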